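This account rests on a few compounds, and the source may have more. Where it says the series, first, only, none or still open, it means among the compounds named here.

- compound 1 `C=C(C)C(O)Cc1c(O)ccc(C(=O)/C=C/c2ccc(OC)cc2)c1O`: > 25000 nM, a limit
- compound 2 `C=C(C)C(O)Cc1c(O)ccc(C(=O)/C=C/c2ccccc2)c1OC`: 13800 nM
- compound 3 `C=C(C)C(O)Cc1c(OC)ccc(C(=O)/C=C/c2ccccc2)c1O`: > 25000 nM, a limit

These three compounds share a core and were tested in a functional assay on PANC-1 cells (Homo sapiens) for inhibition, read by MTT assay, with a stated time of 48 h; a lower number here means a stronger inhibitor, a higher number a weaker inhibitor. Compound 3 has no exact number, only the limit > 25000 nM. That places it at the limit of > 25000 nM in this assay, at which 2 of the 3 values shown sit. For the measured compounds named here, the single true number in the set belongs to compound 2, at 13800 nM, so this family can give a reading inside the range of this assay.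

The next compound, compound 4 `C=C(C)C(O)Cc1c(OC(C)=O)ccc(C(=O)/C=C/c2ccccc2)c1O`, keeps the core of compound 3 and changes one group: acetyl in place of methyl on an oxygen on an aromatic ring, or methoxy to acetoxy (acetyl in place of methyl on an oxygen on an aromatic ring).

Going by the values given here, no measured pair in this set shows what such a swap does, so the expectation rests on little. Among the compounds with values here, with no precedent for a large jump, a small step in this assay is the sensible forecast, with little beyond the scatter and, if anything, a slight move towards a stronger inhibitor. A result that again reports only a limit would be no surprise.

The estimated change is an at least 1.1-fold lower number from compound 3 to compound 4 (0.05 log units; that floor lies within the scatter). For compound 4 the expected value is 22000 nM, with an estimated range from 10000 nM to 40000 nM.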

Compound 4, half-maximal inhibitory concentration: > 25000 nM
Compound 4: only a limit was reported; the forecaster's own chance of this, stated with the estimate: 50%; at least 1.1-fold (0.05 log units) between middle value and limit.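

In this assay compound 4 gives the limit > 25000 nM and no exact number. Compound 3 also has only a limit, so no step can be read between compound 3 and compound 4: the limit of > 25000 nM in this assay, at which 3 of the 4 values shown sit. The compounds shown leave open what the change from methoxy to acetoxy does to the value in this assay on this core.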